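The compounds below may be only part of what the source reports. "The series", "measured", "known", "first", "only" and "open" are said of these compounds alone.

Compound 1 `CCOc1cccc2cc(-c3ccc(OC)cc3)c(=O)oc12`: > 100000 nM
Compound 2 `CCOc1cccc2cc(-c3ccc(OC)c(OC)c3)c(=O)oc12`: > 100000 nM

In an assay on CHO cells for displacement of a labelled ligand from adenosine receptor A1 (Homo sapiens), read by radioligand binding (a lower number here means a stronger inhibitor, a higher number a weaker inhibitor), compound 1 gives > 100000 nM, a limit of the assay. In this assay compound 2 gives > 100000 nM, likewise a limit. The step that the two limits leave unreadable from compound 1 to compound 2 cannot be sized, since both values sit at the limit of > 100000 nM in this assay, at which 2 of the 2 values shown sit. Compound 2 therefore stands at a limit only. Compound 3 `CCOc1cccc2cc(-c3cc(OC)c(OC)c(OC)c3)c(=O)oc12` differs from compound 2 by methoxy in place of hydrogen on an aromatic carbon. Among the measured compounds shown here, no measured step is readable, so no shift beyond the scatter is expected in this assay. Compound 3 is estimated at 100000 nM, in the range 30000 nM to 300000 nM, which is expected to mean a step of a number no higher from compound 2 to compound 3 (the limit leaves the size open).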

Compound 3, inhibition constant: > 100000 nM
Compound 3 was reported as a limit; the forecaster's own chance of this, stated with the estimate: 85%; the middle value sits exactly at the limit.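

Compound 3 sits at a limit in this assay, as compound 2 does, so no step between these two compounds can be read: the limit of > 100000 nM in this assay, at which 3 of the 3 values shown sit.

The compounds shown leave open what effect, if any, each added methoxy has in this assay.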